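The source may report more compounds than this note shows. Statements on the series, on what has been measured and on what is new or still open speak of the compounds shown alone.

Compound 2 `Cc1cc(S(N)(=O)=O)ccc1NC(=O)COc1ccc(Cl)cc1C(O)c1ccc(Cl)c(Cl)c1` carries a 3,4-dichlorophenyl group on a saturated chain carbon bound to an aromatic carbon and an oxygen on a saturated carbon. In an ADME assay on C8166 cells (Homo sapiens) for cytotoxicity, read by MTT assay (on this read-out lower numbers stand for higher toxicity in this test and higher numbers for lower toxicity in this test), compound 2 gives 24000 nM, which sits at the low end of the two numbers measured, yet only within the scatter of its nearest neighbour: compound 1 `Cc1cc(S(N)(=O)=O)ccc1NC(=O)COc1ccc(Cl)cc1C(O)c1cccc(F)c1` gives 37600 nM in this assay, and the step of a 1.6-fold lower number from compound 1 to compound 2 (0.19 log units; within the scatter) stays within the scatter. Compound 3 `Cc1cc(S(N)(=O)=O)ccc1NC(=O)COc1ccc(Cl)cc1C(O)c1ccc2ccccc2c1` differs from compound 2 at that same position: naphthalen-2-yl in place of 3,4-dichlorophenyl on a saturated chain carbon bound to an aromatic carbon and an oxygen on a saturated carbon. Going by the values given here, the one measured step that bears on this change, the aryl swap a 1.6-fold lower number from compound 1 to compound 2 (0.19 log units; within the scatter), did not leave the scatter, and no compound with naphthalen-2-yl has yet been measured in this assay. A step of similar size is therefore expected, not beyond the scatter: a 1.2-fold lower number from compound 2 to compound 3 (0.08 log units; within the scatter). Compound 3 is estimated to give 20000 nM in this assay, with a range of 8000 nM to 50000 nM.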

Compound 3, half-maximal cytotoxic concentration: 15700 nM
The estimate for compound 3 lay 1.3-fold (0.11 log units) above the measured number, and the stated range covers the measured number.
By their numbers in this assay, from the lowest: compounds 3, 2 and 1 (each within the scatter of the next, the first and the last beyond it).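

At the position on a saturated chain carbon bound to an aromatic carbon and an oxygen on a saturated carbon, swapping one aryl group for another now gives a step beyond the scatter in this assay, though a modest one: a 2.4-fold lower number from compound 1 to compound 3 (0.38 log units; beyond the scatter), with naphthalen-2-yl in place of 3-fluorophenyl. With naphthalen-2-yl in place of 3,4-dichlorophenyl, the change stays within the scatter, at a 1.5-fold lower number from compound 2 to compound 3 (0.18 log units; within the scatter), so only the two outer compounds of the three can be told apart. No available evidence explains the difference between compound 1 and compound 3.

As far as these compounds go, it remains open whether a saturated group such as cyclohexyl at this position would give a number near these three. The same holds for a phenyl ring carrying an amine or a carboxylic acid.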